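Pyridyl isomer swap on an acylhydrazone, cytotoxicity expectation

A few compounds are considered here, and "the series" means these few. Any claim that something is new, unique, unknown or untested is made for them only; others in the source may bear on it.

Compound 1 `COc1ccccc1-c1nnc(-c2ccc(C(=O)N/N=C/c3ccncc3)cc2)o1`: 173000 nM
Compound 2 `COc1ccc(O)c(/C=N/NC(=O)c2ccc(-c3nnc(-c4ccccc4OC)o3)cc2)c1`: 303000 nM

In an ADME assay on THP-1 cells (Homo sapiens) for cytotoxicity (on this read-out lower numbers stand for stronger inhibition and higher numbers for weaker inhibition), compound 2 gives 303000 nM, a number within the scatter of compound 1, which gives 173000 nM. Among the compounds with values here, the only measured step, a 1.8-fold higher number from compound 1 to compound 2 (0.24 log units; within the scatter), stays within the scatter. Compound 3 `COc1ccccc1-c1nnc(-c2ccc(C(=O)N/N=C/c3cccnc3)cc2)o1` differs from compound 2 by pyridin-3-yl in place of 2-hydroxy-5-methoxyphenyl on a carbon with a double bond to nitrogen. This change runs opposite to the measured step and also ends on a pyridyl group, so compound 3 is expected to return to the neighbourhood of compound 1, a step of a 1.7-fold lower number from compound 2 to compound 3 (0.23 log units; within the scatter) that would not exceed the scatter. Compound 3 is therefore estimated at 180000 nM, between 90000 nM and 360000 nM.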

Compound 3, half-maximal inhibitory concentration: 167000 nM
Estimate against measurement, compound 3: 1.1-fold (0.03 log units) above, and the stated range covers the measured number.
By their numbers in this assay, from the lowest: compounds 3, 1 and 2 (each within the scatter of the next).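

In this assay, on the carbon with a double bond to nitrogen, pyridin-3-yl in place of pyridin-4-yl gives a 1.0-fold lower number from compound 1 to compound 3 (0.02 log units; within the scatter) and pyridin-3-yl in place of 2-hydroxy-5-methoxyphenyl gives a 1.8-fold lower number from compound 2 to compound 3 (0.26 log units; within the scatter) within the scatter. With three groups now compared at this position, none is told apart from the others on this read-out. No evidence on the reason for this accompanies the numbers.

Going by these compounds, whether an amine, a carboxylic acid or a longer chain at this position would give a step beyond the scatter remains open. Also open, on these data alone, is how any replacement in the shared core would read.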